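Working notes: 4-fluorobenzyl to 4-chlorobenzyl

The compounds below may be only part of what the source reports. "The series", "measured", "known", "first", "only" and "open" are said of these compounds alone.

Compound 1 `Brc1ccccc1CSc1nnc(-c2cnccn2)n1-c1ccccc1`: > 50000 nM (a limit of the assay, not a number)
Compound 2 `Fc1ccc(CSc2nnc(-c3cnccn3)n2-c2ccccc2)cc1`: 7300 nM

Within the data shown here, in a functional assay on HeLa cells (Homo sapiens) for antiproliferative activity, read by MTT assay, with a stated time of 48 h (on this read-out lower numbers stand for stronger inhibition and higher numbers for weaker inhibition), compound 2 gives 7300 nM, the only actual number so far. The other reading is the limit of > 50000 nM in this assay, at which 1 of the 2 values shown sits, and it is a limit.

Compound 3 `Clc1ccc(CSc2nnc(-c3cnccn3)n2-c2ccccc2)cc1` differs from compound 2 by chloro in place of fluoro on an aromatic carbon, para to a large group.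

Among the measured compounds shown here, the one measured step, an at least 6.8-fold lower number from compound 1 to compound 2 (0.83 log units; beyond the scatter), put 4-fluorophenyl in place of 2-bromophenyl. That is a wider change than the present one, so it bears on it only loosely. For the measured compounds named here, no measured step compares chloro with fluoro directly. No step beyond the scatter is therefore expected in this assay, and neither direction is favoured.

The expected change is a 1.1-fold lower number from compound 2 to compound 3 (0.05 log units; within the scatter).

Compound 3 is expected at 6500 nM, with an estimated range of 2500 nM to 20000 nM.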

Compound 3, half-maximal inhibitory concentration: > 50000 nM
Compound 3: only a limit was reported; the forecaster's own chance of this, stated with the estimate: 10%; middle value at least 7.6-fold (0.88 log units) away from the limit.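

Among these compounds, on the aromatic carbon para to a large group, chloro in place of fluoro gives an at least 6.8-fold higher number from compound 2 to compound 3 (0.83 log units; beyond the scatter) in this assay, so a single exchange of one halogen at this position is enough to move the read-out beyond the scatter, which the wider change between the earlier compounds could not show. Compound 3 reads > 50000 nM, a limit of the assay and not a number, so the step has a lower bound only. In this set, 4-fluorobenzyl remains the only group that gives an actual number: the limit of > 50000 nM in this assay, at which 2 of the 3 values shown sit.

The step from compound 1 to compound 3 cannot be read, so 2-bromophenyl and 4-chlorophenyl stay unranked against each other. Open too, from the compounds shown here alone, is whether a methoxy, an amine or a plain hydrogen at this position would stay in the measurable range as compound 2 does.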